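The compounds below may be only part of what the source reports. "The series", "measured", "known", "first", "only" and "open" are said of these compounds alone.

Measured so far in an ADME assay on L02 cells (Homo sapiens) for cytotoxicity, read by MTT assay, with a stated time of 72 h; on this read-out lower numbers stand for stronger inhibition and higher numbers for weaker inhibition:
Compound 1 `CCC/C=C/C(=O)Nc1cccc(Oc2nc(Nc3ccn(C)n3)nc3c2CSCC3)c1`: > 50000 nM (a limit, not a number)
Compound 2 `CC/C=C/C(=O)Nc1cccc(Oc2nc(Nc3ccc(OC)nc3)nc3c2CSCC3)c1`: > 50000 nM (a limit, not a number)

Compound 2 stands at > 50000 nM, which is a limit of the assay, so no number is known for it. It does not stand alone there, as the two compounds together show (the limit of > 50000 nM in this assay, at which 2 of the 2 values shown sit).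

Compound 3 `CCC/C=C/C(=O)Nc1cccc(Oc2nc(Nc3ccc(OC)nc3)nc3c2CSCC3)c1` departs from compound 2 in a single place: methyl in place of hydrogen on a saturated chain carbon, two bonds along the chain from a double-bonded chain carbon. This is methyl in place of hydrogen on a saturated chain carbon, two bonds along the chain from a double-bonded chain carbon, and it turns but-1-en-1-yl into pent-1-en-1-yl.

For the measured compounds named here, no measured step between two compounds is available to size such a change in this assay. The expectation therefore rests on the small size of the change and on compound 2 at > 50000 nM. No shift in either direction beyond the usual scatter is expected, and another limit is the likeliest report. The estimated step, a number no higher from compound 2 to compound 3 (the limit leaves the size open), is expected to stay within the scatter. For compound 3 the expected value is 50000 nM, with an estimated range of 25000 nM to 100000 nM.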

Compound 3, half-maximal inhibitory concentration: > 50000 nM
Compound 3 was reported as a limit; the forecaster's own chance of this, stated with the estimate: 85%; the middle value sits exactly at the limit.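

Compound 3, like compound 1 and compound 2, is reported in this assay only as a limit, so no step from compound 1 or compound 2 to compound 3 can be read: the limit of > 50000 nM in this assay, at which 3 of the 3 values shown sit.

The compounds shown leave open what the actual values are, and whether either change, from but-1-en-1-yl to pent-1-en-1-yl or from 1-methyl-1H-pyrazol-3-yl to 6-methoxypyridin-3-yl, shifts them at all.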